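The source may report more compounds than this note shows. Statements on the series, on what has been measured and on what is new or still open speak of the compounds shown alone.

Measured compounds:
- Compound 1, `COc1cc(-c2cc(/C=C/C(=O)c3ccc(Cl)c(Cl)c3)[nH]n2)cc(OC)c1OC`: -5%
- Compound 2, `COc1ccc(C(=O)/C=C/c2cc(-c3cc(OC)c(OC)c(OC)c3)n[nH]2)cc1OC`: -99%

Both were tested in a functional assay on U-251 cells (Homo sapiens) for cytotoxicity, read by sulforhodamine B assay, with a stated time of 48 h, tested at 100 uM; on this read-out lower numbers stand for a stronger effect and higher numbers for a weaker effect at the one concentration tested. Compound 2 has the lowest of the two numbers, and its nearest neighbour is compound 1, which differs from it in a single place. Going by the values given here, that single step, a number 94 percentage points lower from compound 1 to compound 2 (beyond the scatter), is the only measured change available and it is large: replacing 3,4-dichlorophenyl with 3,4-dimethoxyphenyl on the carbonyl carbon moved the read-out from a weak effect to a very strong one.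

Compound 3, `COc1cc(-c2cc(/C=C/C(=O)c3ccc(F)c(F)c3)[nH]n2)cc(OC)c1OC`, has not yet been measured. It differs from compound 2 as follows: 3,4-difluorophenyl in place of 3,4-dimethoxyphenyl on a carbonyl carbon. The change undoes the dimethoxy substitution and puts a halogenated ring back on the carbonyl carbon, this time with fluorine rather than chlorine. Since the measured step shows the dimethoxy ring in this position to be what separates compound 2 from compound 1, compound 3 is expected to sit closer to compound 1 than to compound 2, giving a large step upward, a number 69 percentage points higher from compound 2 to compound 3 (beyond the scatter). For compound 3 the expected value is -30%, with a range from -90% to 10%.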

Compound 3, a percentage reported as activity, at one concentration (the size of the read-out at that concentration, not a potency): -29%
Estimate against measurement, compound 3: 1 percentage points below; low and high end bracket the measured number.
By their numbers in this assay, from the lowest: compound 2; then compound 3; then compound 1.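

In this assay, the carbonyl carbon now carries three different rings, and the 3,4-dimethoxyphenyl ring remains the one with the strongest effect: returning to a halogenated ring gives a number 70 percentage points higher from compound 2 to compound 3 (beyond the scatter) and loses much of that effect. Compound 3 also shows that the two halogenated rings cannot be treated as equivalent, since changing the halogens alone gives a number 24 percentage points lower from compound 1 to compound 3 (beyond the scatter) and this modest step still lies beyond the usual scatter, so the read-out depends on which halogen is present and not simply on whether the ring carries halogens. The data offer no measured property that could explain this order among the three rings.

On these data alone, it remains open whether both methoxy groups of compound 2 are needed, and how a plain phenyl ring or a ring bearing a hydroxyl or dimethylamino group would compare on this carbonyl carbon. These readings also come from a single concentration, so they say nothing about how potency would rank across a full range of concentrations.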